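A few compounds are considered here, and "the series" means these few. Any claim that something is new, unique, unknown or untested is made for them only; others in the source may bear on it.

Compound 1 `COc1cc(N(C)CCN(C)C)c(NC(=O)C(Cl)=C(Cl)Cl)cc1Nc1nccc(-c2cn(C)c3ccccc23)n1`: > 50000 nM (a limit)
Compound 2 `COc1cc(N(C)CCN(C)C)c(NC(=O)C=C(C)C)cc1Nc1nccc(-c2cn(C)c3ccccc23)n1`: 5660 nM

Within the data shown here, in a functional assay on HepG2 cells (Homo sapiens) for antiproliferative activity, read by MTT assay, with a stated time of 72 h (a lower number here means a stronger inhibitor, a higher number a weaker inhibitor), compound 2 gives 5660 nM, the only true number so far. Compound 1 reads > 50000 nM, which is a limit of the assay and not a number. Compound 3 `CCC/C=C\C(=O)Nc1cc(Nc2nccc(-c3cn(C)c4ccccc34)n2)c(OC)cc1N(C)CCN(C)C` differs from compound 2 in one group: pent-1-en-1-yl in place of 2-methylprop-1-en-1-yl on a carbonyl carbon. Among the measured compounds shown here, the one measured step, an at least 8.8-fold lower number from compound 1 to compound 2 (0.94 log units; beyond the scatter), also changed the group on the carbonyl carbon, but it removed 1,2,2-trichloroethenyl, which plays no part in the new change, so it offers only a loose guide. In this assay the expected step is a 1.1-fold higher number from compound 2 to compound 3 (0.03 log units; within the scatter), probably none beyond the scatter, with neither direction favoured. For compound 3 the estimated value is 6000 nM, with an expected range of 2000 nM to 20000 nM.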

Compound 3, half-maximal inhibitory concentration: 431 nM
Beside the measured number, compound 3's estimate is 14-fold (1.14 log units) above it, outside the stated range (below it).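

In this assay, this position proves far more sensitive than the first pair could show: replacing 2-methylprop-1-en-1-yl with pent-1-en-1-yl gives a 13-fold lower number from compound 2 to compound 3 (1.12 log units; beyond the scatter), though the group only goes from 4 to 5 carbon atoms and keeps its double bond. Set against 1,2,2-trichloroethenyl, the same group gives an at least 110-fold lower number from compound 1 to compound 3 (2.06 log units; beyond the scatter). The reading for compound 1 is a limit and not a number: the limit of > 50000 nM in this assay, at which 1 of the 3 values shown sits.

The compounds shown do not separate the effect of chain length from that of branching. Going by these compounds, a longer chain, a saturated pentyl group or an amine on this carbonyl carbon remains open.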